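Replacing the 3,4-dihydroxyphenyl group of compound 2

The source may report more compounds than this note shows. Statements on the series, on what has been measured and on what is new or still open speak of the compounds shown alone.

In a functional assay on HL-60 cells (Homo sapiens) for inhibition, read by CCK-8 assay, with a stated time of 48 h (a lower number here means a stronger inhibitor, a higher number a weaker inhibitor), compound 1 `O=C(NCCNS(=O)(=O)c1ccc(-c2ccccc2OCc2cccc(O)c2)s1)Nc1cc(Cl)cc(Cl)c1` gives 2800 nM. For the measured compounds named here, compound 2 `O=C(NCCNS(=O)(=O)c1ccc(-c2ccccc2Oc2ccc(O)c(O)c2)s1)Nc1cc(Cl)cc(Cl)c1` gives 10400 nM, the higher of the two numbers measured so far. Compound 3 `O=C(NCCNS(=O)(=O)c1ccc(-c2ccccc2Oc2ccc([N+](=O)[O-])c([N+](=O)[O-])c2)s1)Nc1cc(Cl)cc(Cl)c1` carries 3,4-dinitrophenyl in place of 3,4-dihydroxyphenyl on an oxygen on an aromatic ring. Going by the values given here, one measured step bears on this place: a 3.7-fold higher number from compound 1 to compound 2 (0.57 log units; beyond the scatter), a modest step beyond the scatter, with 3,4-dihydroxyphenyl in place of 3-hydroxybenzyl. That step shows that a change here can shift the number modestly, but neither measured compound carries a nitro group, so it fixes no direction for this change. The estimated change is a 1.5-fold lower number from compound 2 to compound 3 (0.17 log units; within the scatter), which is not expected to lie beyond the scatter. Compound 3 is estimated at 7000 nM, with an expected range from 2000 nM to 25000 nM.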

Compound 3, half-maximal inhibitory concentration: 2300 nM
Estimate against measurement, compound 3: 3.0-fold (0.48 log units) above, and the stated range covers the measured number.
By their numbers in this assay, from the lowest: compounds 3 and 1 (each within the scatter of the next); then compound 2.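

In this assay, putting 3,4-dinitrophenyl in place of 3,4-dihydroxyphenyl gives a 4.5-fold lower number from compound 2 to compound 3 (0.66 log units; beyond the scatter) on the oxygen on an aromatic ring, so a change at this place can also lower the number, and the gap to the 3,4-dihydroxyphenyl group is of about the size of the earlier step. Against 3-hydroxybenzyl, the same group gives a 1.2-fold lower number from compound 1 to compound 3 (0.09 log units; within the scatter) and so leaves no order between those two, which makes compound 2 the only one of the three set apart by a step beyond the scatter. Nothing shown gives a reason for these steps.

On these data alone, it remains open how a phenyl group carrying a single nitro group, an amine or a carboxylic acid would compare with compound 3 at this place. Also open, as far as these compounds go, is whether a longer chain on the same oxygen would keep the number of compound 3.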